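A Second Fluoro on the Ring of Compound 3

This account rests on a few compounds, and the source may have more. Where it says the series, first, only, none or still open, it means among the compounds named here.

In a functional assay on HeLa cells (Homo sapiens) for antiproliferative activity, read by MTT assay, with a stated time of 48 h (on this read-out higher numbers stand for weaker inhibition and lower numbers for stronger inhibition), compound 3 (`Fc1ccc(CSc2nnc(-c3cnccn3)n2-c2ccccc2)cc1`) gives 7300 nM. Compound 2 (`Brc1cccc(CSc2nnc(-c3cnccn3)n2-c2ccccc2)c1`), with a 3-bromophenyl group in its place, gives 9580 nM. The step between them is a 1.3-fold lower number from compound 2 to compound 3 (0.12 log units; within the scatter), so the two cannot be told apart. Compound 1 (`Clc1ccccc1CSc1nnc(-c2cnccn2)n1-c1ccccc1`), which carries a 2-chlorophenyl group, reads > 50000 nM, and this is a limit and not a number.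

Compound 4 (`Fc1ccc(CSc2nnc(-c3cnccn3)n2-c2ccccc2)c(F)c1`) turns the 4-fluorophenyl of compound 3 into 2,4-difluorophenyl: fluoro in place of hydrogen on an aromatic carbon. Among the compounds with values here, the new fluoro sits ortho to a large group, and compound 1 is the only measured compound that also has a group there. That makes two steps relevant: an at least 6.8-fold lower number from compound 1 to compound 3 (0.83 log units; beyond the scatter) and an at least 5.2-fold lower number from compound 1 to compound 2 (0.71 log units; beyond the scatter). Both suggest that a group at this place may cost activity in this assay. However, this rests on compound 1 alone, and its group is a chloro, not a fluoro. A modest move toward weaker inhibition is therefore expected, and a step within the scatter remains possible. The estimated change is a 1.5-fold higher number from compound 3 to compound 4 (0.18 log units; within the scatter). For compound 4, the expected value is 11000 nM, with an estimated range of 4500 nM to 35000 nM.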

Compound 4, half-maximal inhibitory concentration: 12500 nM
Compound 4: middle estimate off by 1.1-fold (0.06 log units), on the low side, and the stated range covers the measured number.
By their numbers in this assay, from the lowest: compounds 3, 2 and 4 (each within the scatter of the next). At a limit, above all of these: compound 1.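

In this assay, adding the fluoro gives a 1.7-fold higher number from compound 3 to compound 4 (0.23 log units; within the scatter), and replacing the 3-bromophenyl with 2,4-difluorophenyl gives a 1.3-fold higher number from compound 2 to compound 4 (0.12 log units; within the scatter), so compounds 2, 3 and 4 cannot be told apart. What is new is that a group ortho to the large group does not always bring the reading close to that of compound 1, as the change from 2-chlorophenyl to 2,4-difluorophenyl gives an at least 4.0-fold lower number from compound 1 to compound 4 (0.60 log units; beyond the scatter). Compound 1 remains a limit and not a number: the limit of > 50000 nM in this assay, at which 1 of the 4 values shown sits.

The compounds shown leave open whether the gap to compound 1 belongs to the chloro itself or to the second fluoro that compound 4 also carries, as the two rings differ in both. They also leave open how a methoxy group, a hydroxyl or an amine on this same ring carbon would read, and whether a longer chain in place of the saturated chain carbon bound to the sulfur would move the number beyond the scatter.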